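The compounds below may be only part of what the source reports. "The series", "measured", "known", "first", "only" and "open" are said of these compounds alone.

Measured in a functional assay on the whole organism with Rattus norvegicus as the target, read by paw edema, in the formalin test, with a stated time of 3 h; a lower number here means that less compound is needed, a higher number that more compound is needed for the effect:
- compound 1 `NS(=O)(=O)c1ccc(N2N=C(c3ccco3)CC2c2ccc(C(F)(F)F)cc2)cc1`: "not active" (no number reported)
- compound 2 `CS(=O)(=O)c1ccc(N2N=C(C(=O)O)CC2c2cccs2)cc1`: 169 umol/kg
- compound 3 `NS(=O)(=O)c1ccc(N2N=C(c3ccco3)CC2c2ccco2)cc1`: 383 umol/kg

Compound 1 has no number to start from, since it is reported only as "not active" (no number reported). Compound 4 `NS(=O)(=O)c1ccc(N2N=C(c3ccco3)CC2c2cccs2)cc1` keeps the rest of compound 1 and changes one group, thiophen-2-yl in place of 4-(trifluoromethyl)phenyl on a saturated ring carbon. Within the data shown here, no measured pair shows this change directly. Compound 2, which also carries thiophen-2-yl there but differs elsewhere, gives 169 umol/kg. Compound 3, with furan-2-yl there, gives 383 umol/kg. In this assay, the expected step is therefore a large one, from no measurable effect to a measurable dose. For compound 4 the estimated dose is 260 umol/kg, with an expected range of 110 umol/kg to 600 umol/kg.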

Compound 4, dose for half-maximal effect: 469 umol/kg
Compound 4: middle estimate off by 1.8-fold (0.26 log units), on the low side, and the stated range covers the measured number.
By their numbers in this assay, from the lowest: compound 2; then compounds 3 and 4 (each within the scatter of the next).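

In this assay, thiophen-2-yl in place of furan-2-yl on the saturated ring carbon gives a 1.2-fold higher number from compound 3 to compound 4 (0.09 log units; within the scatter) and so does not separate these two rings. Compound 1 with 4-(trifluoromethyl)phenyl there gives "not active" (no number reported) while compound 4 gives 469 umol/kg and thus, among these compounds, a measurable dose appears only with a five-membered aromatic ring at this place. Nothing shown explains this difference. As far as these compounds go, whether plain phenyl, without trifluoromethyl, would also give a measurable dose remains open. So does the outcome with a saturated group such as cyclohexyl.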